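A few compounds are considered here, and "the series" means these few. Any claim that something is new, unique, unknown or untested is made for them only; others in the source may bear on it.

Going by the values given here, only two compounds built on this shared core have been measured so far in a toxicity assay on THP-1 cells (Homo sapiens) for inhibition; on this read-out higher numbers stand for lower toxicity in this test and lower numbers for higher toxicity in this test. Compound 1 `Cn1c(-c2ccc(Br)cc2)cnc1NC(=O)c1ccc(F)cc1`, which carries a 4-bromophenyl group, gives 46000 nM. Compound 2 `Cn1c(-c2cccc(C#N)c2)cnc1NC(=O)c1ccc(F)cc1`, which carries a 3-cyanophenyl group, gives > 100000 nM, and this is a limit of the assay rather than a number. Compound 2 therefore stands at the limit of > 100000 nM in this assay, at which 1 of the 2 values shown sits.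

Compound 3 `Cn1c(-c2cccc(Cl)c2)cnc1NC(=O)c1ccc(F)cc1` has chloro in place of cyano on an aromatic carbon. Among the compounds with values here, only one measured step bears on this change, namely an at least 2.1-fold higher number from compound 1 to compound 2 (0.33 log units; beyond the scatter). That step also took a halogen away and brought the cyano group in, but it differs from the new change in both the halogen and its place, so it is only a rough guide. Reversing its direction, a modest move towards a lower number in this assay is expected, with compound 1 at 46000 nM as the nearest reference. The expected size of the change is an at least 1.8-fold lower number from compound 2 to compound 3 (0.25 log units; that floor lies within the scatter). For compound 3 the estimated value is 55000 nM, with an expected range of 22000 nM to 100000 nM.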

Compound 3, half-maximal cytotoxic concentration: > 50000 nM
Compound 3 ended at the assay's limit; the forecaster's own chance of this, stated with the estimate: 35%; the middle value is on the limit's open side.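

In this assay, the 3-chlorophenyl compound joins the 3-cyanophenyl one in giving a limit rather than a number, so this position now holds two such readings: the limit of > 50000 nM in this assay, at which 1 of the 3 values shown sits. Chloro and cyano sit on the same aromatic carbon, which makes compound 2 and compound 3 a clean one-place pair, yet the step between them cannot be read, so neither group can be ranked against the other in this test. Set against the 4-bromophenyl group, the 3-chlorophenyl group gives an at least 1.0-fold higher number from compound 1 to compound 3 (0.03 log units; that floor lies within the scatter), so the new compound shows no clear separation from the bromo compound, and the change from a halogen to cyano at this place cannot be tied to any real shift.

The shown compounds change both the halogen and its place on the ring in a single step, so the effect of each remains unresolved, and a true number for compound 3 is still lacking. Going by these compounds, how an amine or a carboxylic acid on this aromatic carbon would read in this assay also remains open.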